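Fluoro for Methoxy on a Pyrazole Carboxamide: Tolerance Expected

The source may report more compounds than this note shows. Statements on the series, on what has been measured and on what is new or still open speak of the compounds shown alone.

Compound 1, `CC(C)Cc1nn(-c2cccc(F)c2)cc1C(=O)NCc1ccc(F)cc1`, gives in a toxicity assay on HepG2 2.2.15 cells (Homo sapiens) for cytotoxicity, read by CCK-8 assay, with a stated time of 8 days (a higher number here means that more compound is tolerated, a lower number that less compound is tolerated), only the limit > 100000 nM.
Compound 2, `CC(C)Cc1nn(-c2nccs2)cc1C(=O)Nc1ccc(F)cc1`, gives in this assay a value of 83700 nM.
Compound 3, `COc1ccc(CNC(=O)c2cn(-c3nccs3)nc2CC(C)C)cc1`, gives in this assay only the limit > 100000 nM.

Compound 3 therefore stands at the limit of this assay rather than at a measured number, and it shares that position with one further compound (the limit of > 100000 nM in this assay, at which 2 of the 3 values shown sit). Among the measured compounds shown here, compound 2 is the only compound with a numerical value. Compound 4, `CC(C)Cc1nn(-c2nccs2)cc1C(=O)NCc1ccc(F)cc1`, differs from compound 3 in one place: fluoro in place of methoxy on an aromatic carbon, on an aromatic carbon of a six-membered aromatic ring of carbon only, para to a large group. Compound 1 carries the same 4-fluorophenyl group and also reached only the limit. For the measured compounds named here, no step between measured compounds is available, so no measured size of change can be quoted. A step from compound 3 to compound 4 of a number no higher from compound 3 to compound 4 (the limit leaves the size open) is expected, which is none beyond the scatter. Compound 4 is expected to give in this assay about 100000 nM, within 60000 nM to 200000 nM, most likely again reported only as the limit.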

Compound 4, half-maximal cytotoxic concentration: > 100000 nM
Compound 4 was reported as a limit; the forecaster's own chance of this, stated with the estimate: 70%; the middle value lies on the limit itself.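

In this assay compound 4 gives > 100000 nM, which is a limit of the assay and not a number, so the fluoro group at this place, para to a large group, leaves the read-out at a limit just as the methoxy group did. The steps that link compound 4 to the two other limit compounds cannot be read. Among the compounds shown here, the one readable comparison is 4-fluorobenzyl in place of 4-fluorophenyl on the amide-type nitrogen, which gives an at least 1.1-fold higher number from compound 2 to compound 4 (0.07 log units; that floor lies within the scatter), and that floor shows no change beyond the scatter.

As far as these compounds go, the read-out leaves little room for comparison in this set: the limit of > 100000 nM in this assay, at which 3 of the 4 values shown sit. Whether an amine, a carboxylic acid or a longer chain at this place on the ring would give a measurable number remains open, as does how far the true values of compound 1, compound 3 and compound 4 lie past the limit.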